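A few compounds are considered here, and "the series" means these few. Any claim that something is new, unique, unknown or untested is made for them only; others in the source may bear on it.

Compound 3 `O=C(c1ccccc1-c1ccncc1)N1CCC(O)(Cc2ccccc2)CC1` gives 7.9 nM in an assay for inhibition of cholesterol 24-hydroxylase (Homo sapiens), using NADPH, with stated times of 15 min and 5 min; on this read-out higher numbers stand for weaker inhibition and lower numbers for stronger inhibition. Of the three numbers measured, it sits closest to compound 2 `Cc1ccc(C(=O)N2CCC(O)(Cc3ccccc3)CC2)c(-c2ccncc2)c1`, which gives 4.4 nM, a gap within the scatter, while compound 1 `Cc1cccc(C(=O)N2CCC(O)(Cc3ccccc3)CC2)c1-c1ccncc1` gives 130 nM, a gap beyond it. The two recorded steps, a 16-fold lower number from compound 1 to compound 3 (1.22 log units; beyond the scatter) and a 1.8-fold higher number from compound 2 to compound 3 (0.25 log units; within the scatter), both concern hydrogen in place of methyl on an aromatic carbon and leave the pyridin-4-yl untouched. Compound 4 `O=C(c1ccccc1-c1ccncn1)N1CCC(O)(Cc2ccccc2)CC1` carries pyrimidin-4-yl in place of pyridin-4-yl on an aromatic carbon. For the measured compounds named here, no measured step bears on this change, so there is no basis to expect a shift beyond the scatter in either direction. Compound 4 is estimated at 10 nM, between 3 nM and 40 nM. That estimate means an expected 1.3-fold higher number from compound 3 to compound 4 (0.10 log units; within the scatter), within the scatter.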

Compound 4, half-maximal inhibitory concentration: 4.3 nM
The estimate for compound 4 lay 2.3-fold (0.37 log units) above the measured number, within the range that was stated.
By their numbers in this assay, from the lowest: compounds 4, 2 and 3 (each within the scatter of the next); then compound 1.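

In this assay the swap gives a 1.8-fold lower number from compound 3 to compound 4 (0.26 log units; within the scatter) and so shows that a second ring nitrogen, with a second hydrogen-bond acceptor, can stand at this place, ortho to a large group, with no change beyond the scatter. For the compounds shown here, the earlier steps concerned only hydrogen in place of methyl, so this is the first change to the pyridin-4-yl itself. No available evidence explains this result.

From the compounds shown here alone, whether a plain phenyl or a pyrazin-2-yl at this place would give a similar number remains open.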